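The source may report more compounds than this note shows. Statements on the series, on what has been measured and on what is new or still open speak of the compounds shown alone.

Compound 1 `CCCCCCCCCCCCNC[C@@H]1OC[C@H](N)[C@@H]1O` and compound 2 `CCCCCCCCCCCNC[C@@H]1OC[C@H](N)[C@H]1O` share a core, but the difference between the two cores is not broken down here. In a functional assay on MCF7 cells (Homo sapiens) for antiproliferative activity, read by MTT assay, with a stated time of 72 h (a higher number here means a weaker inhibitor, a lower number a stronger inhibitor), compound 1 gives 1800 nM, and compound 2 gives 13100 nM. Compound 3 `CCCCCCCCNC[C@@H]1OC[C@H](N)[C@H]1O` follows from compound 2 by hydrogen in place of propyl on a saturated chain carbon, eight bonds along the chain from an amine nitrogen. In this assay compound 3 reaches only a limit, > 128000 nM, and at that limit (the limit of > 128000 nM in this assay, at which 1 of the 3 values shown sits). The step of an at least 9.7-fold higher number from compound 2 to compound 3 (0.98 log units; beyond the scatter) is therefore a lower bound on how much this shortening costs.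

Compound 4 `CCCCCCCCCNC[C@@H]1OC[C@H](N)[C@@H]1O` is not yet measured in this assay. It follows from compound 1 by hydrogen in place of propyl on a saturated chain carbon, nine bonds along the chain from an amine nitrogen, which is the same kind of change as that from compound 2 to compound 3, the place differing only in that the chain carbon sits nine bonds rather than eight bonds along the chain from the amine nitrogen. For compound 4 the expected step is a 14-fold higher number from compound 1 to compound 4 (1.14 log units; beyond the scatter), resting on the measured step of an at least 9.7-fold higher number from compound 2 to compound 3 (0.98 log units; beyond the scatter) from compound 2 to compound 3. The estimate for compound 4 in this assay is 25000 nM, with an expected range from 8000 nM to 110000 nM.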

Compound 4, half-maximal inhibitory concentration: 12500 nM
For compound 4 the middle estimate is 2.0-fold (0.30 log units) above the measured one; the measured number falls inside the stated range.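

On the core of compound 1, this shortening of the chain also raises the number in this assay, with a step of a 6.9-fold higher number from compound 1 to compound 4 (0.84 log units; beyond the scatter), so the change points the same way on both cores: the same change on two cores in this assay, an at least 9.7-fold higher number (0.98 log units; beyond the scatter) from compound 2 to compound 3 and a 6.9-fold higher number (0.84 log units; beyond the scatter) from compound 1 to compound 4; the limit leaves it open whether they differ For compound 3 the reading in this assay is a limit, > 128000 nM, and not a number. The direction of the change therefore carries from one core to the other in these two pairs, but whether its size carries over cannot be told, and two pairs give no rule for any further core: the limit of > 128000 nM in this assay, at which 1 of the 4 values shown sits.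

The compounds shown leave open how a longer chain, or a chain ending in an amine or a carboxylic acid, would behave on either core. Among them, no pair carries the same chain on the two cores, so the contribution of the core alone remains unresolved.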